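Coumarin Furoxan Hybrid with a Methylsulfamoylamino Aryl Group

The source may hold more compounds than are shown below. What is called first, only, known or untested is meant among the compounds shown, and "the series" means these compounds.

Three compounds carrying the same phenylsulfonyl furoxan unit on an ethylene linker have been measured in a functional assay on MCF7 cells (Homo sapiens) for antiproliferative activity, read by MTT assay, with a stated time of 48 h; a lower number here means a stronger inhibitor, a higher number a weaker inhibitor. Compound 1, `COCCOc1no[n+]([O-])c1S(=O)(=O)c1ccccc1`, the bare linker compound, gives 3500 nM. Compound 2, `Cc1c(Cc2ccc(F)cc2)c(=O)oc2cc(OCCOc3no[n+]([O-])c3S(=O)(=O)c3ccccc3)ccc12`, gives 2850 nM in this assay, and compound 3, `COc1cc(OCCOc2no[n+]([O-])c2S(=O)(=O)c2ccccc2)ccc1C(=O)/C=C/c1ccccc1`, gives 1870 nM in this assay. Compound 2 sits in the middle of these three numbers; its distance to compound 1 and its distance to compound 3 both lie within the scatter of the method, so the three cannot be told apart on these data.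

Compound 4, `CNS(=O)(=O)Nc1cccc(Cc2c(C)c3ccc(OCCOc4no[n+]([O-])c4S(=O)(=O)c4ccccc4)cc3oc2=O)c1`, has not yet been measured. It differs from compound 2 at one place: 3-((methylsulfamoyl)amino)phenyl in place of 4-fluorophenyl on a saturated chain carbon bound to an aromatic carbon.

Going by the values given here, no pair of measured compounds differing in one place has been measured, so there is no step of this kind on which to lean. The measured values, all close to one another, give no hint that this kind of substituent change moves this assay strongly. The author therefore expects the step from compound 2 to compound 4 to be a 1.1-fold lower number from compound 2 to compound 4 (0.06 log units; within the scatter), that is, a change not clearly beyond the scatter in either direction. For compound 4 the estimate in this assay is 2500 nM, with a range from 900 nM to 7000 nM.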

Compound 4, half-maximal inhibitory concentration: 3130 nM
Beside the measured number, compound 4's estimate is 1.3-fold (0.10 log units) below it; low and high end bracket the measured number.
By their numbers in this assay, from the lowest: compounds 3, 2, 4 and 1 (each within the scatter of the next).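

Going by these compounds alone, at the place on a saturated chain carbon bound to an aromatic carbon, compound 4 gives the first readable step in this assay: 3-((methylsulfamoyl)amino)phenyl in place of 4-fluorophenyl gives a 1.1-fold higher number from compound 2 to compound 4 (0.04 log units; within the scatter) on the shared core. The entering group is larger and carries hydrogen-bond donors and acceptors, which the leaving group lacks, yet this exchange cannot be told apart from no change at all in this read-out, so these differences in the group have no visible consequence here. No measured property of these compounds is at hand to bear on this result.

The compounds shown leave open whether any group at this place can move the number in this assay beyond the scatter, for example a carboxylic acid or a primary amine on the phenyl ring, or a longer chain carrying that ring. They also leave open how the two parts of the exchange contribute, since 3-fluorophenyl, which would separate the ring position from the methylsulfamoylamino group, is not among them.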